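Trihydroxyphenyl Ester Expected to Extend the Hydroxyphenyl Gain

The compounds below may be only part of what the source reports. "The series", "measured", "known", "first", "only" and "open" are said of these compounds alone.

Compound 1 `COc1ccc(C2CC(=NO)CC(c3ccc(OC)cc3)N2C)cc1` gives 380000 nM in a functional assay, with a stated time of 30 min (a lower number here means a stronger inhibitor, a higher number a weaker inhibitor), the highest of the three numbers measured. Compound 2 `COc1ccc(C2CC(=NOC(=O)c3cccc(Cl)c3)CC(c3ccc(OC)cc3)N2C)cc1` gives 136000 nM and compound 3 `COc1ccc(C2CC(=NOC(=O)c3cccc(O)c3)CC(c3ccc(OC)cc3)N2C)cc1` gives 34000 nM. The unmeasured compound 4 `COc1ccc(C2CC(=NOC(=O)c3cc(O)c(O)c(O)c3)CC(c3ccc(OC)cc3)N2C)cc1` differs from compound 1 in one place: (3,4,5-trihydroxyphenyl)carbonyl in place of hydrogen on an oxygen. Going by the values given here, two measured steps bear on this change. The step of a 2.8-fold lower number from compound 1 to compound 2 (0.45 log units; beyond the scatter) was modest, whereas an 11-fold lower number from compound 1 to compound 3 (1.05 log units; beyond the scatter) was large, and among the esters a 4.0-fold lower number from compound 2 to compound 3 (0.60 log units; beyond the scatter) favoured hydroxy over chloro. The entering group of compound 4 carries the hydroxyphenyl carbonyl seen in compound 3 with two further hydroxy groups. A large drop in the number is therefore expected for compound 4, a 25-fold lower number from compound 1 to compound 4 (1.40 log units; beyond the scatter). Compound 4 is estimated at 15000 nM, with a range from 4000 nM to 60000 nM.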

Compound 4, half-maximal inhibitory concentration: 18000 nM
Compound 4: the middle estimate sits 1.2-fold (0.08 log units) below what was measured; measured number inside the range.
By their numbers in this assay, from the lowest: compounds 4 and 3 (each within the scatter of the next); then compound 2; then compound 1.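

At the oxygen bonded to the double-bonded nitrogen, in this assay, the (3,4,5-trihydroxyphenyl)carbonyl group gives a 21-fold lower number from compound 1 to compound 4 (1.32 log units; beyond the scatter) and so keeps the large gain of the ester with one hydroxy group. Yet the two further hydroxy groups give no separable gain, as a 1.9-fold lower number from compound 3 to compound 4 (0.28 log units; within the scatter) shows, while a 7.6-fold lower number from compound 2 to compound 4 (0.88 log units; beyond the scatter) leaves the chloro ester behind compound 4. The compounds shown leave open whether an amine or a carboxylic acid on the entering group, or a longer chain in place of its aromatic ring, would bring the number lower than in compound 3 and compound 4. Nothing given here accounts for these steps.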